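A few compounds are considered here, and "the series" means these few. Any claim that something is new, unique, unknown or untested is made for them only; others in the source may bear on it.

Measured compounds and their values:

compound 1, `CCCSc1nc(N/N=C(\C)c2ccc(OC)cc2)c2nnn(Cc3ccccc3)c2n1`, > 64000 nM
compound 2, `CCCSc1nc(N/N=C/c2ccccc2F)c2nnn(Cc3ccccc3)c2n1`, > 64000 nM
compound 3, `CCCSc1nc(N/N=C(\C)c2ccccc2O)c2nnn(Cc3ccco3)c2n1`, 5760 nM

All three share a core and were tested in a functional assay on ECa-109 cells (Homo sapiens) for antiproliferative activity, read by MTT assay, with a stated time of 72 h; on this read-out higher numbers stand for weaker inhibition and lower numbers for stronger inhibition. Compound 2 gives only a limit in this assay, > 64000 nM, which is not a measured number but the edge of what the test can report. Compound 2 is not alone there: the limit of > 64000 nM in this assay, at which 2 of the 3 values shown sit. Among the measured compounds shown here, the one measured number comes from compound 3, which gives 5760 nM in this assay and so shows that a compound of this family can be measured as an actual value.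

The next compound, compound 4, is `CCCSc1nc(N/N=C/c2ccccc2Cl)c2nnn(Cc3ccccc3)c2n1`. It differs from compound 2 in a single place: chloro in place of fluoro on an aromatic carbon. For the measured compounds named here, no pair of measured compounds shows the effect of this change, so there is nothing measured to lean on. The expectation is that the step from compound 2 to compound 4 stays small, a step that the limit leaves unreadable from compound 2 to compound 4, within the usual scatter. Compound 4 is therefore estimated at 70000 nM, in a range from 15000 nM to 300000 nM, most likely reported again as a limit.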

Compound 4, half-maximal inhibitory concentration: 6180 nM
Estimate against measurement, compound 4: 11-fold (1.05 log units) above, outside the stated range (below it).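

In this assay, the change from 2-fluorophenyl to 2-chlorophenyl gives an at least 10-fold lower number from compound 2 to compound 4 (1.01 log units; beyond the scatter). This is the first step shown between two compounds that differ in one place, and it shows that swapping a single atom on this aromatic carbon, ortho to a large group, can move the read-out a long way. The printed size is only a lower bound on the step, since compound 2 has a limit and not a number: the limit of > 64000 nM in this assay, at which 2 of the 4 values shown sit.

Why chloro and fluoro differ so much here cannot be told from these compounds, and one pair cannot show whether the same change would act alike elsewhere on the shared core. As far as these compounds go, it also remains open whether a bromo or a methyl group at this position would give a number close to that of compound 4.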